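The compounds below may be only part of what the source reports. "The series", "measured", "known", "first", "only" and "open" are said of these compounds alone.

Working notes on the series. In a functional assay on CHO cells for positive allosteric modulation of metabotropic glutamate receptor 2 (Homo sapiens), read by scintillation counting and GTPgammaS binding, with a stated time of 30 min (on this read-out lower numbers stand for an effect already at smaller amounts and higher numbers for an effect only at larger amounts of compound), compound 1 `CC(C)CCn1ccc(-c2ccc(Oc3ccncc3)cc2)c(C#N)c1=O` gives 550 nM. Compound 2 `Cc1cc(Oc2ccc(-c3ccn(CCC(C)C)c(=O)c3C#N)cc2)ccn1` carries methyl in place of hydrogen on an aromatic carbon and in this assay gives 447 nM, so a 1.2-fold lower number from compound 1 to compound 2 (0.09 log units; within the scatter). Compound 3 `CCCCn1ccc(-c2ccc(Oc3cccnc3C)c(Cl)c2)c(C#N)c1=O` gives 100 nM in this assay, the lowest of the three numbers, its steps to the other two lying beyond the scatter; how its core differs from that of compound 1 is not broken down here. Compound 4 `CCCCn1ccc(-c2ccc(Oc3ccc(C)nc3C)c(Cl)c2)c(C#N)c1=O` has not yet been measured and differs from compound 3 by methyl in place of hydrogen on an aromatic carbon. This is the same kind of change as from compound 1 to compound 2, though the surroundings differ: in compound 2 the methyl is meta to a large group, in compound 4 it is meta to a methyl group (1 heavy atom) and para to a large group. Because a 1.2-fold lower number from compound 1 to compound 2 (0.09 log units; within the scatter) stayed within the scatter, a similarly small step is expected for compound 4, a 1.2-fold lower number from compound 3 to compound 4 (0.07 log units; within the scatter). Compound 4 is thus estimated at 85 nM in this assay, with a likely range from 35 nM to 200 nM.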

Compound 4, half-maximal effective concentration: 30 nM
For compound 4 the middle estimate is 2.8-fold (0.45 log units) above the measured one; the measured number lies below the stated range.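

In this assay, methyl in place of hydrogen next to the ring nitrogen gives a 3.3-fold lower number from compound 3 to compound 4 (0.52 log units; beyond the scatter). Set beside the earlier step, this change does not carry over at one size from core to core: the same change on two cores in this assay, a 1.2-fold lower number (0.09 log units; within the scatter) from compound 1 to compound 2 and a 3.3-fold lower number (0.52 log units; beyond the scatter) from compound 3 to compound 4, 2.7-fold (0.43 log units) apart, beyond the scatter of two such steps.
Within the data shown here, only two pairs bear on this, and the methyl stands in different surroundings in each, so the data do not show whether the core or the place of the methyl sets the size of the step.

Open, going by these compounds, is whether an ethyl or a methoxy group in the place of this methyl gives a step of like size. Also open, on these data alone, is whether the change from (2-methylpyridin-3-yl)oxy to (2,6-dimethylpyridin-3-yl)oxy gives the same step on other cores.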